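The source may hold more compounds than are shown below. What is called first, only, known or untested is meant among the compounds shown, and "the series" means these compounds.

Compound 2 `COC(=O)C(=O)CNC1=CS(=O)(=O)O[C@@]12[C@@H](CO[Si](C)(C)C(C)(C)C)O[C@@H](n1cc(C)c(=O)n(C)c1=O)[C@@H]2O[Si](C)(C)C(C)(C)C` is examined in a functional assay on HEL cells (Homo sapiens) for cytotoxicity, read by microscopy (a higher number here means that more compound is tolerated, a lower number that less compound is tolerated), which asks how much of a compound the cells tolerate. Compound 2 reaches only a limit there, > 400000 nM, not a number. Compound 1 `CCNC(=O)NC1=CS(=O)(=O)O[C@@]12[C@@H](CO[Si](C)(C)C(C)(C)C)O[C@@H](n1cc(C)c(=O)n(C)c1=O)[C@@H]2O[Si](C)(C)C(C)(C)C` likewise stops at a limit, >= 3200 nM. Compound 3 `Cc1cn([C@@H]2O[C@H](CO[Si](C)(C)C(C)(C)C)[C@@]3(OS(=O)(=O)C=C3NCCC(N)=O)[C@H]2O[Si](C)(C)C(C)(C)C)c(=O)n(C)c1=O` also stops at a limit, >= 80000 nM. Compound 4 `CCOC(=O)CNC(=O)NC1=CS(=O)(=O)O[C@@]12[C@@H](CO[Si](C)(C)C(C)(C)C)O[C@@H](n1cc(C)c(=O)n(C)c1=O)[C@@H]2O[Si](C)(C)C(C)(C)C` is not yet measured; it differs from compound 2 by ((ethoxycarbonyl)methyl)carbamoyl in place of ((methoxycarbonyl)carbonyl)methyl on an amine nitrogen. The measured steps are a step that the two limits leave unreadable from compound 1 to compound 2, a step that the two limits leave unreadable from compound 1 to compound 3 and a step that the two limits leave unreadable from compound 2 to compound 3; none of them has a readable size, so no direction and no size can be drawn for the present change. Compound 4 is therefore expected to sit again at a limit, estimated at 100000 nM within 3200 nM to 400000 nM. The expected step of an at least 4.0-fold lower number from compound 2 to compound 4 (0.60 log units; beyond the scatter) is thus an estimate with no firm size.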

Compound 4, minimum cytotoxic concentration: 16000 nM
Estimate against measurement, compound 4: 6.3-fold (0.80 log units) above; the measured number falls inside the stated range.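

In this assay, going by these compounds alone, compound 4 is the only compound here with a number rather than a limit, so this amine nitrogen is a place where the substituent can clearly change how much compound the cells tolerate. With ((ethoxycarbonyl)methyl)carbamoyl entering, the data show an at least 25-fold lower number from compound 2 to compound 4 (1.39 log units; beyond the scatter), and also an at least 5.0-fold lower number from compound 3 to compound 4 (0.69 log units; beyond the scatter). Nothing given here explains these drops.

From the compounds shown here alone, the step from compound 1 cannot be read, so it stays open whether the ethoxycarbonyl group matters on the carbamoyl chain. Also open, going by these compounds, is how a carboxylic acid in place of the ethyl ester would behave.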